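This account rests on a few compounds, and the source may have more. Where it says the series, first, only, none or still open, it means among the compounds named here.

Compound 1 `CC(C(=O)NCc1ccc(C(F)(F)F)nc1)c1ccc(NS(C)(=O)=O)c(F)c1` carries a hydrogen at the position of interest, and in a functional assay on CHO-K1 cells for antagonist activity at transient receptor potential cation channel subfamily V member 1 (Homo sapiens), read by FLIPR (a higher number here means a weaker inhibitor, a lower number a stronger inhibitor), compound 1 gives "not active" (no number reported), so no number places it on a scale. Compound 4 `CC(C(=O)NCc1ccc(C(F)(F)F)nc1N(C)C)c1ccc(NS(C)(=O)=O)c(F)c1` differs from it by dimethylamino in place of hydrogen on an aromatic carbon. Within the data shown here, no measured step covers this exact change, but two related compounds show what happens when that hydrogen is replaced by a larger group on a nitrogen: compound 2 `CC(C(=O)NCc1ccc(C(F)(F)F)nc1NC1CCCCC1)c1ccc(NS(C)(=O)=O)c(F)c1` gives 260 nM in this assay, and compound 3 `CC(C(=O)NCc1ccc(C(F)(F)F)nc1NCc1ccccc1)c1ccc(NS(C)(=O)=O)c(F)c1` gives 203 nM, with a 1.3-fold lower number from compound 2 to compound 3 (0.11 log units; within the scatter). Both substituted compounds are therefore measurably active where compound 1 is not, so a substituent here seems to bring activity. For compound 4, with its smaller dimethylamino group, the estimate is 1000 nM, within a range of 250 nM to 5000 nM.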

Compound 4, half-maximal inhibitory concentration: 2390 nM
Compound 4: the middle estimate sits 2.4-fold (0.38 log units) below what was measured, and the stated range covers the measured number.
By their numbers in this assay, from the lowest: compounds 3 and 2 (each within the scatter of the next); then compound 4.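

Dimethylamino on this aromatic carbon is enough to give compound 4 a measurable number, where compound 1, with hydrogen there, has none. Even so, dimethylamino is clearly poorer than benzylamino or cyclohexylamino, with a 12-fold higher number from compound 3 to compound 4 (1.07 log units; beyond the scatter) and a 9.2-fold higher number from compound 2 to compound 4 (0.96 log units; beyond the scatter). No measurement shown here explains that gap. The compounds shown leave open whether the amino hydrogen kept by compound 2 and compound 3 matters, or only the bulk of the group. Methylamino, which keeps that hydrogen, or a ring amine such as morpholine, which lacks it, would help separate the two.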